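From a Stilbene Arm to a Biaryl Arm

This account rests on a few compounds, and the source may have more. Where it says the series, first, only, none or still open, it means among the compounds named here.

Measured compounds:
compound 1 `COC(=O)/C=C/c1cccc(N(Cc2ccc(/C=C/c3c(F)cccc3F)cc2)C(=O)C(C)C)c1`: 108 nM
compound 2 `COC(=O)/C=C/c1cccc(N(Cc2ccc(/C=C/c3ccccc3F)cc2)C(=O)NC(C)C)c1`: 431 nM
compound 3 `COC(=O)/C=C/c1cccc(N(Cc2ccc(/C=C/c3ccc(F)cc3)cc2)C(=O)NC(C)C)c1`: 348 nM

In an assay on isolated protein with Bile acid receptor (Homo sapiens) as the target (a higher number here means that more compound is needed for the effect, a lower number that less compound is needed), compound 1 gives the lowest number of the three, with compound 3 and compound 2 both standing beyond the scatter above it. Compound 4 `COC(=O)/C=C/c1cccc(N(Cc2ccc(-c3ccc(SC)cc3)cc2)C(=O)C(C)C)c1` is not yet measured. It differs from compound 1 by 4-(methylsulfanyl)phenyl in place of 2-(2,6-difluorophenyl)ethenyl on an aromatic carbon. Going by the values given here, the only measured step, a 1.2-fold lower number from compound 2 to compound 3 (0.09 log units; within the scatter), moves a fluorine on an otherwise unchanged arm and stays within the scatter; no measured pair removes the double bond outside the aromatic rings or brings in a methylsulfanyl group, so nothing here matches the change. The expectation therefore rests on compound 1 alone. A step toward a higher number is estimated, a 2.8-fold higher number from compound 1 to compound 4 (0.44 log units; beyond the scatter). Compound 4 is expected at 300 nM, within 80 nM to 1200 nM.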

Compound 4, half-maximal effective concentration: 51 nM
Compound 4: the middle estimate sits 5.9-fold (0.77 log units) above what was measured, outside the stated range (below it).
By their numbers in this assay, from the lowest: compound 4; then compound 1; then compounds 3 and 2 (each within the scatter of the next).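

In this assay, a phenyl ring bound directly at this aromatic carbon does not cost anything compared with the ethenyl arm: the change gives a 2.1-fold lower number from compound 1 to compound 4 (0.33 log units; beyond the scatter) and still leaves the number low. For this pair, then, the double bond outside the aromatic rings is not needed for a low number. No measurement here explains the shift.

The change removes the double bond and the fluorines and adds the methylsulfanyl group all at once, and the compounds shown do not separate these parts. As far as these compounds go, what a methoxy group in place of the methylsulfanyl group would do, or a carboxylic acid in place of the methyl ester, stays open.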